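Lipophilicity notes: compound 4 weighed against compound 2

This account rests on a few compounds, and the source may have more. Where it says the series, first, only, none or still open, it means among the compounds named here.

Among the measured compounds shown here, compound 2 `CC[C@@H](Nc1c(C#N)c(-c2ccc(-c3ccccc3C(F)(F)F)cc2)nc2cnccc12)C(N)=O` gives 3.1 in a physicochemical assay for lipophilicity, read by HPLC, at pH 7.5 (on this read-out higher numbers stand for higher lipophilicity and lower numbers for lower lipophilicity), the highest of the three numbers measured so far. Compound 1 `CC[C@@H](Nc1c(C#N)c(-c2ccc(-c3cccc(OC)c3)cc2)nc2cnccc12)C(N)=O` gives 2.7, and compound 3 `CCOc1ccccc1-c1ccc(-c2nc3cnccc3c(NC(C)C(=O)O)c2C#N)cc1` gives 2.1; compound 3 differs from the others in more than one place, so only its value is noted. For the measured compounds named here, the single one-place step, a number 0.40 log units higher from compound 1 to compound 2 (beyond the scatter), is modest yet beyond the scatter. Compound 4 `CC[C@@H](Nc1c(C#N)c(-c2ccc(-c3cccc(C)c3F)cc2)nc2cnccc12)C(N)=O` is not yet measured; it changes compound 2 by 2-fluoro-3-methylphenyl in place of 2-(trifluoromethyl)phenyl on an aromatic carbon. Going by the values given here, no measured step covers this exact exchange. Because a number 0.40 log units higher from compound 1 to compound 2 (beyond the scatter) shows a swap of the terminal ring shifting this assay only modestly, compound 4 is expected to sit near compound 2, with an expected step of a number 0.10 log units lower from compound 2 to compound 4 (within the scatter), within the scatter. Compound 4 is estimated at 3, ranging from 2.6 to 3.4.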

Compound 4, distribution coefficient: 3
Compound 4: the middle estimate sits on the measured number at the digits printed; the measured number falls inside the stated range.
By their numbers in this assay, from the lowest: compound 3; then compounds 1, 4 and 2 (each within the scatter of the next, the first and the last beyond it).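

On the aromatic carbon para to a large group, 2-fluoro-3-methylphenyl in place of 2-(trifluoromethyl)phenyl gives a number 0.10 log units lower from compound 2 to compound 4 (within the scatter) in this assay, so trifluoromethyl is not required to keep the number at this level. The same ring in place of 3-methoxyphenyl gives a number 0.30 log units higher from compound 1 to compound 4 (within the scatter), leaving the step from compound 1 to compound 2 as the only one among these three rings that lies beyond the scatter. Nothing available explains these steps.

From the compounds shown here alone, whether a terminal ring bearing an amine or a carboxylic acid would stay in this range remains open. Compound 3 differs in more than one place, so its steps cannot be read.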